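The source may report more compounds than this note shows. Statements on the series, on what has been measured and on what is new or still open speak of the compounds shown alone.

Going by the values given here, compound 3 `CCCc1ccc(NC2=CC(=O)c3c(nc4n3[C@H]3OC[C@@H](O)[C@H]3OC4)C2=O)cc1` gives the highest of the three numbers so far in a functional assay on MGC-803 cells (Homo sapiens) for inhibition, read by sulforhodamine B assay (on this read-out lower numbers stand for stronger inhibition and higher numbers for weaker inhibition), at 1920 nM. Compound 1 `Cc1ccc(NC2=CC(=O)c3nc4n(c3C2=O)[C@H]2OC[C@@H](O)[C@H]2OC4)cc1` gives 1420 nM in this assay, within the scatter of compound 3, while compound 2 `Cc1ccc(NC2=CC(=O)c3nc4n(c3C2=O)[C@H]2OC[C@@H](O)[C@H]2OC4)cc1C` gives 860 nM, beyond it. Among the compounds with values here, the one measured step, a 1.7-fold lower number from compound 1 to compound 2 (0.22 log units; within the scatter), lies within the scatter. Compound 4 `CCOc1ccc(NC2=CC(=O)c3c(nc4n3[C@H]3OC[C@@H](O)[C@H]3OC4)C2=O)cc1` differs from compound 3 by ethoxy in place of propyl on an aromatic carbon. Within the data shown here, no measured step involves a change of this kind, so nothing in the set bears directly on it, and the only step available is small. Compound 4 is therefore expected to show a 1.1-fold lower number from compound 3 to compound 4 (0.05 log units; within the scatter), with no step beyond the scatter. Compound 4 is estimated at 1700 nM in this assay, in a range from 700 nM to 4200 nM.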

Compound 4, half-maximal inhibitory concentration: 2090 nM
Beside the measured number, compound 4's estimate is 1.2-fold (0.09 log units) below it, within the range that was stated.
By their numbers in this assay, from the lowest: compounds 2, 1, 3 and 4 (each within the scatter of the next, the first and the last beyond it).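

Ethoxy in place of propyl on this aromatic carbon, para to a large group, gives a 1.1-fold higher number from compound 3 to compound 4 (0.04 log units; within the scatter) in this assay and so stays within the scatter. At this position, then, adding a hydrogen-bond acceptor while keeping the same heavy-atom count leaves 4-propylphenyl and 4-ethoxyphenyl indistinguishable, which the earlier methyl step could not show. No available evidence accounts for this result.

As far as these compounds go, whether an amine, a carboxylic acid or a longer chain here would move the number beyond the scatter remains open.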